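Series notes: the step from compound 2 to compound 3

A few compounds are considered here, and "the series" means these few. Any claim that something is new, unique, unknown or untested is made for them only; others in the source may bear on it.

Two compounds have numbers. Compound 1 `CC(C(=O)NCc1ccc(C(F)(F)F)nc1N(C)C)c1ccc(NS(C)(=O)=O)c(F)c1` carries a dimethylamino group where compound 2 `Cc1ccc(CC2CCN(c3nc(C(F)(F)F)ccc3CNC(=O)C(C)c3ccc(NS(C)(=O)=O)c(F)c3)CC2)cc1` carries the larger saturated ring bearing a 4-methylbenzyl group. In a functional assay on CHO-K1 cells for antagonist activity at transient receptor potential cation channel subfamily V member 1 (Homo sapiens), read by FLIPR (a higher number here means a weaker inhibitor, a lower number a stronger inhibitor), compound 1 gives 2390 nM. In this assay compound 2 gives 17 nM, the lowest of the two numbers; the gap to compound 1 lies well beyond the scatter. Compound 3 `CC(C(=O)NCc1ccc(C(F)(F)F)nc1N1CCC(Cc2ccc(F)c(F)c2)CC1)c1ccc(NS(C)(=O)=O)c(F)c1` differs from compound 2 in one place: 3,4-difluorophenyl in place of 4-methylphenyl on a saturated chain carbon bound to a saturated ring carbon. Among the compounds with values here, no step between measured compounds covers a change of this kind, so the expectation rests on compound 2 alone. The exchange keeps the ring count and adds no donors or acceptors, so the step in this assay is expected to be small, at most a modest shift and possibly none beyond the scatter. For compound 3 the expected value is 25 nM (range 8 nM to 80 nM). This corresponds to an expected step of a 1.5-fold higher number from compound 2 to compound 3 (0.17 log units; within the scatter).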

Compound 3, half-maximal inhibitory concentration: 30 nM
Compound 3: the middle estimate sits 1.2-fold (0.08 log units) below what was measured; the measured number falls inside the stated range.
By their numbers in this assay, from the lowest: compounds 2 and 3 (each within the scatter of the next); then compound 1.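

In this assay the exchange of 4-methylbenzyl for 3,4-difluorobenzyl gives a 1.8-fold higher number from compound 2 to compound 3 (0.25 log units; within the scatter) and so leaves the two compounds indistinguishable. Within the data shown here, this is the first reading of a change at the phenyl end of this substituent, and it shows that the value of compound 2 does not depend on the 4-methylphenyl group alone, since 3,4-difluorophenyl serves equally well on a saturated chain carbon bound to a saturated ring carbon. No measured data bear on why the two groups read alike.

Two closely matched aryl groups say little about how wide this tolerance runs, so an amine or a carboxylic acid on the phenyl ring remains an open test. Also open, from the compounds shown here alone, is whether a longer chain in place of the benzyl carbon would hold the value of compound 3.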